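This account rests on a few compounds, and the source may have more. Where it says the series, first, only, none or still open, it means among the compounds named here.

Series notes: three measured compounds and one open position in a functional assay on MCF7 cells (Homo sapiens) for inhibition, read by MTT assay, with a stated time of 72 h; a lower number here means a stronger inhibitor, a higher number a weaker inhibitor.

Compound 1 `CCCCCc1c(C)nc2nc(SCc3ccc(Cl)cc3)nn2c1Nc1cc(-c2ccccc2)[nH]n1` carries the shared core with a pentyl chain and a phenyl-bearing pyrazole on the amine; in this assay compound 1 gives 6390 nM. Compound 3 `Cc1cc(Nc2cc(-c3ccccc3)[nH]n2)n2nc(SCc3ccc(C(F)(F)F)cc3)nc2n1` keeps the phenyl-bearing pyrazole but shifts the thioether aryl to a trifluoromethyl group; in this assay compound 3 gives 4820 nM. Compound 2 `Cc1cc(Nc2ccn(Cc3nc(C)c4ccccc4n3)n2)n2nc(SCc3ccc(Br)cc3)nc2n1` instead carries a (4-methylquinazolin-2-yl)methyl on the pyrazole nitrogen and a bromine on the thioether aryl; in this assay compound 2 gives 1430 nM, the lowest number of the three, and its gaps to compound 3 and to compound 1 both lie beyond the scatter.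

Compound 4 `Cc1cc(Nc2ccn(Cc3ccccc3)n2)n2nc(SCc3ccc(Br)cc3)nc2n1` is the next member, not yet measured. It differs from compound 2 in one place: phenyl in place of 4-methylquinazolin-2-yl on a saturated chain carbon bound to an aromatic nitrogen. Going by the values given here, no single-point step between measured compounds is available to calibrate this change, since compounds 1 and 3 differ from compound 2 in more than one place.

Expectation for compound 4: a modest weakening, with the step of a 1.7-fold higher number from compound 2 to compound 4 (0.24 log units; within the scatter) expected to sit close to the edge of the scatter rather than clearly beyond it. For compound 4 in this assay the estimate is 2500 nM, with a likely range from 900 nM to 7000 nM.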

Compound 4, half-maximal inhibitory concentration: 15800 nM
The estimate for compound 4 lay 6.3-fold (0.80 log units) below the measured number; the whole stated range lies below it.
By their numbers in this assay, from the lowest: compound 2; then compounds 3 and 1 (each within the scatter of the next); then compound 4.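

In this assay, going by these compounds alone, replacing 4-methylquinazolin-2-yl with phenyl on a saturated chain carbon bound to an aromatic nitrogen gives an 11-fold higher number from compound 2 to compound 4 (1.04 log units; beyond the scatter) and provides the first single-place step, showing that the number is highly sensitive to the group at this position. The change removes 11 heavy atoms, including 2 nitrogen, and 2 hydrogen-bond acceptors, and brings in 6 heavy atoms with 0 hydrogen-bond acceptors, so the loss of the second ring and the loss of both ring nitrogens occur together in this one step. No supporting measurement is available to explain the size of this step.

The compounds shown leave open whether the difference follows the second ring, the ring nitrogens or the methyl group, which a naphthalen-2-yl, a pyridin-2-yl or an unsubstituted quinazolin-2-yl on the same chain carbon could help separate. They also leave open whether this step would hold with a chlorine or a trifluoromethyl group on the thioether aryl in place of the bromine of compound 2 and compound 4.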